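Aryl Amide in Place of Butyramide on the Shared Core

The compounds below may be only part of what the source reports. "The series", "measured", "known", "first", "only" and "open" are said of these compounds alone.

Compound 1, `COc1ccc(OCC(=O)Nc2cccc(NC(=O)c3ccc(N(C)C)cc3)c2)cc1OC`, gives in an assay on isolated protein for inhibition of Rho-associated protein kinase 1 (Homo sapiens), read by scintillation counting, radiometric assay and 33P incorporation, with a stated time of 40 min, in the presence of a further agent that is not named here (on this read-out higher numbers stand for weaker inhibition and lower numbers for stronger inhibition), only a limit of the assay, > 10000 nM. Compound 2, `CC(=O)c1ccc(OCC(=O)Nc2cccc(NC(=O)c3ccc(N(C)C)cc3)c2)cc1F`, gives 445 nM. Compound 3, `CCCC(=O)Nc1cccc(NC(=O)COc2ccc3c(=O)ccoc3c2)c1`, gives 1430 nM.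

Compound 3 stands highest of the two numbers; the nearest is compound 2, whose number is lower by a gap beyond the scatter. Within the data shown here, the one measured step, an at least 22-fold lower number from compound 1 to compound 2 (1.35 log units; beyond the scatter), concerns the oxygen-linked aryl side and so does not bear on the change now considered. Compound 4, `CC(C)(C)c1ccc(C(=O)Nc2cccc(NC(=O)COc3ccc4c(=O)ccoc4c3)c2)cc1`, differs from compound 3 by 4-(tert-butyl)phenyl in place of propyl on a carbonyl carbon. Among the measured compounds shown here, no measured step covers this exchange; compound 2 carries an aryl amide at that place and gives 445 nM. Compound 4 is expected to give 800 nM, between 200 nM and 4000 nM. That estimate means an expected 1.8-fold lower number from compound 3 to compound 4 (0.25 log units; within the scatter).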

Compound 4, half-maximal inhibitory concentration: 165 nM
The estimate for compound 4 lay 4.8-fold (0.69 log units) above the measured number; measured number below the stated range.
By their numbers in this assay, from the lowest: compound 4; then compound 2; then compound 3. At a limit, above all of these: compound 1.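

In this assay, among these compounds, exchanging propyl for 4-(tert-butyl)phenyl on a carbonyl carbon brings an 8.7-fold lower number from compound 3 to compound 4 (0.94 log units; beyond the scatter), the only measured step at this place. This place of the shared core therefore accepts a substituted phenyl ring, and the exchange strengthens inhibition by a margin beyond the scatter. Nothing measured here gives a cause for this gain.

From the compounds shown here alone, it remains open whether the gain belongs to the ring or to the tert-butyl group on it. A plain phenyl, a longer alkyl chain or a piperidine at this place would separate these possibilities.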